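A few compounds are considered here, and "the series" means these few. Any claim that something is new, unique, unknown or untested is made for them only; others in the source may bear on it.

Measured in a functional assay on SW-620 cells (Homo sapiens) for cytotoxicity, read by sulforhodamine B assay, with a stated time of 48 h; a lower number here means a stronger inhibitor, a higher number a weaker inhibitor:
- compound 1 `COc1ccc(C2=NO[C@]3(C2)C(=O)O[C@@H]2[C@H]3CC[C@H](C)[C@]3(O)C=CC(=O)[C@@]23C)cc1`: 41000 nM
- compound 2 `C[C@H]1CC[C@@H]2[C@@H](OC(=O)[C@]23CC(c2ccc(N(C)C)cc2)=NO3)[C@]2(C)C(=O)C=C[C@@]12O`: 5100 nM
- compound 3 `COc1cc(C2=NO[C@]3(C2)C(=O)O[C@@H]2[C@H]3CC[C@H](C)[C@]3(O)C=CC(=O)[C@@]23C)ccc1O`: 88000 nM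

Of these three, compound 3 carries the highest number and is the weakest inhibitor, with its gaps to both others beyond the scatter. Compound 4 `C[C@H]1CC[C@@H]2[C@@H](OC(=O)[C@]23CC(c2cccc([N+](=O)[O-])c2)=NO3)[C@]2(C)C(=O)C=C[C@@]12O` keeps the shared core and differs from compound 3 at one place: 3-nitrophenyl in place of 4-hydroxy-3-methoxyphenyl on a carbon with a double bond to nitrogen. Its 3-nitrophenyl group has not been measured on this core, so the available steps give only indirect guidance. All of them are changes to the same aromatic group: a 2.1-fold higher number from compound 1 to compound 3 (0.33 log units; beyond the scatter) is modest, a 17-fold higher number from compound 2 to compound 3 (1.24 log units; beyond the scatter) is large, and an 8.0-fold lower number from compound 1 to compound 2 (0.91 log units; beyond the scatter) is modest. Compound 3, at 88000 nM, sits at the top of this range, so any change from it is more likely to lower the number than to raise it. The expected result in this assay is a 2.9-fold lower number from compound 3 to compound 4 (0.47 log units; beyond the scatter), a modest step. The estimated value for compound 4 is 30000 nM, with an expected range of 8000 nM to 100000 nM.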

Compound 4, half-maximal inhibitory concentration: 49000 nM
Beside the measured number, compound 4's estimate is 1.6-fold (0.21 log units) below it; low and high end bracket the measured number.
By their numbers in this assay, from the lowest: compound 2; then compounds 1, 4 and 3 (each within the scatter of the next, the first and the last beyond it).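

With 3-nitrophenyl on the carbon with a double bond to nitrogen, this assay shows a 1.8-fold lower number from compound 3 to compound 4 (0.25 log units; within the scatter) and a 1.2-fold higher number from compound 1 to compound 4 (0.08 log units; within the scatter), so this group, which has no hydrogen-bond donor, cannot be told apart from either 4-hydroxy-3-methoxyphenyl or 4-methoxyphenyl. Going by these compounds alone, the 4-(dimethylamino)phenyl group stands apart, with a 9.6-fold higher number from compound 2 to compound 4 (0.98 log units; beyond the scatter), leaving compound 2 the strongest inhibitor of the four and the only one whose steps to all the others lie beyond the scatter. Nothing available explains why this one group differs from the other three.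

These compounds leave open whether the lower number of compound 2 depends on the dimethylamino group itself or would also appear with a primary amine or a diethylamino group on the same phenyl ring. They also leave open how a carboxylic acid would behave there.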